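Fluorine Removal on an Aromatic Ring: Expected Antiproliferative Effect

A few compounds are considered here, and "the series" means these few. Any claim that something is new, unique, unknown or untested is made for them only; others in the source may bear on it.

Compound 1 `COc1cc(CCc2cccc(F)c2)cc(OC)c1O` gives 2240 nM.
Compound 2 `COc1ccc(CCc2ccc([N+](=O)[O-])cc2)cc1OC` gives > 25000 nM, which is a limit of the assay.
Compound 3 `COc1ccc(CCc2ccccn2)cc1OC` gives > 25000 nM, which is also a limit of the assay.

These three compounds were tested in a functional assay on A549 cells (Homo sapiens) for antiproliferative activity, read by MTT assay, with a stated time of 72 h; on this read-out lower numbers stand for stronger inhibition and higher numbers for weaker inhibition. Compound 1 is the only one with a numerical result; the other two reach only a limit, as noted in the limit of > 25000 nM in this assay, at which 2 of the 3 values shown sit. No pair of these compounds differs in a single place, so no measured step is available.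

Compound 4 `COc1cc(CCc2ccccc2)cc(OC)c1O` has not yet been tested. It differs from compound 1 by hydrogen in place of fluoro on an aromatic carbon; the change sits on an aromatic carbon of a six-membered aromatic ring of carbon only, meta to a large group. Among the compounds with values here, since no measured step involves this change, the expectation rests on compound 1 alone and on the small size of the alteration. The step of a 1.3-fold higher number from compound 1 to compound 4 (0.13 log units; within the scatter) is expected to stay within the usual scatter, with no clear direction. Compound 4 is therefore estimated at 3000 nM, with a range from 1000 nM to 9000 nM.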

Compound 4, half-maximal inhibitory concentration: 10900 nM
The estimate for compound 4 lay 3.6-fold (0.56 log units) below the measured number; measured number outside the range, above it.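

Replacing the fluoro with hydrogen on this aromatic carbon, meta to a large group, gives in this assay a 4.9-fold higher number from compound 1 to compound 4 (0.69 log units; beyond the scatter). Within the data shown here, this is the first measured step, and it shows that a change of a single atom at this place weakens the inhibition of cell growth by a modest margin that exceeds the usual scatter. Compound 4 still gives a number, unlike compound 2 and compound 3, which each give only a limit of the assay: the limit of > 25000 nM in this assay, at which 2 of the 4 values shown sit.

From the compounds shown here alone, whether a chloro, a methyl or an amine at this place would match the fluoro remains open. Going by these compounds, it is also open whether a fluoro on another carbon of the same ring would give a similar result.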